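Swapping 3,4-difluorophenyl for oxan-4-yl at a solubility limit

A few compounds are considered here, and "the series" means these few. Any claim that something is new, unique, unknown or untested is made for them only; others in the source may bear on it.

Compound 1 `Fc1ccc(-c2nc3cnc(Nc4ccccn4)cc3[nH]2)cc1F`: >= 50000 nM
Compound 2 `Fc1ccc(-c2nc3cnc(Nc4ccc(C(F)(F)F)cn4)cc3[nH]2)cc1F`: >= 50000 nM
Compound 3 `Fc1ccc(Nc2cc3[nH]c(-c4ccc(F)c(F)c4)nc3cn2)nc1`: >= 50000 nM

These three results come from a physicochemical assay for solubility, using the shake flask method, in simulated intestinal fluid, measured as kinetic solubility, with a stated time of 20 h, at pH 6.5 (a lower number here means a less soluble compound, a higher number a more soluble compound), and each is a limit of the assay rather than a number. Compound 2 therefore stands only at its limit of >= 50000 nM. The series as a whole sits at the limit of >= 50000 nM in this assay, at which 3 of the 3 values shown sit.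

The step followed here leads to compound 4 `FC(F)(F)c1ccc(Nc2cc3[nH]c(C4CCOCC4)nc3cn2)nc1`, which carries oxan-4-yl in place of 3,4-difluorophenyl on an aromatic carbon. Among the measured compounds shown here, none of the measured steps changes the 3,4-difluorophenyl group. Trifluoromethyl in place of hydrogen gives a step that the two limits leave unreadable from compound 1 to compound 2. Fluoro in place of hydrogen gives a step that the two limits leave unreadable from compound 1 to compound 3. Fluoro in place of trifluoromethyl gives a step that the two limits leave unreadable from compound 2 to compound 3. These steps offer no size to carry over to the new change, so no step beyond the scatter is expected in this assay, and no direction can be given. The expectation rests on compound 2, whose >= 50000 nM is a limit. The estimated step is a number no higher from compound 2 to compound 4 (the limit leaves the size open). Compound 4 may well be reported only as a limit too. Compound 4 is estimated at 50000 nM, with an expected range of 25000 nM to 100000 nM.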

Compound 4, solubility: 168000 nM
Estimate against measurement, compound 4: 3.4-fold (0.53 log units) below, outside the stated range (above it).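

Compound 2 is reported only as a limit, >= 50000 nM. Among the compounds shown here, compound 4 has a measured number, but no step from compound 2 to compound 4 can be read. The compounds shown leave open the size and direction of the change from 3,4-difluorophenyl to oxan-4-yl: compound 1, compound 2 and compound 3, which all carry 3,4-difluorophenyl, stand at limits.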